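The source may hold more compounds than are shown below. What is called first, only, known or untested is meant among the compounds shown, and "the series" means these compounds.

In a functional assay on MDBK cells (Bos taurus) for cytotoxicity (a higher number here means that more compound is tolerated, a lower number that less compound is tolerated), compound 2 `Cc1ccc(O)c(C(=O)NCCCN2CCC[C@@H]3CCCC[C@H]32)c1` gives 60 ug/mL, and compound 1 `Cc1ccc(O)c(C(=O)NCCCN2[C@H](C)CC[C@@H]3CCCC[C@@H]32)c1` gives 35 ug/mL; the two numbers lie within the scatter of each other, so neither stands apart. Compound 3 `Cc1ccc(O)c(C(=O)NCCCN2[C@@H]3CCCC[C@H]3CC[C@@H]2C)c1` differs from compound 2 by methyl in place of hydrogen on a saturated ring carbon. Among the compounds with values here, no measured pair shows this change on this core, so no step beyond the scatter is expected; a somewhat lower number is thought slightly more likely because compound 1, which also carries a methyl, gives 35 ug/mL. Compound 3 is estimated at 45 ug/mL in this assay, between 25 ug/mL and 80 ug/mL. The step this estimate implies is a 1.3-fold lower number from compound 2 to compound 3 (0.12 log units; within the scatter), expected to remain within the scatter.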

Compound 3, half-maximal cytotoxic concentration: 30 ug/mL
Compound 3: the middle estimate sits 1.5-fold (0.18 log units) above what was measured; the measured number falls inside the stated range.
By their numbers in this assay, from the lowest: compounds 3, 1 and 2 (each within the scatter of the next).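

In this assay, methyl in place of hydrogen on the saturated ring carbon next to the ring nitrogen now has a measured step on this core: a 2.0-fold lower number from compound 2 to compound 3 (0.30 log units; within the scatter). Configuration alone gives a 1.2-fold lower number from compound 1 to compound 3 (0.07 log units; within the scatter), so neither change moves the number beyond the scatter. That second step can be read for configuration alone because of this: the fact that compounds 1 and 3 differ only in the configuration as drawn

Open, on these data alone, is whether ethyl or hydroxymethyl on this ring carbon would give a step beyond the scatter. Also open, as far as these compounds go, is whether the remaining stereo element matters in this assay.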